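The compounds below may be only part of what the source reports. "The series", "measured", "known", "first", "only" and "open" are said of these compounds alone.

Compound 1 `COc1cccc(C(=O)c2ccc(OC)c(OC(=O)CCC(=O)OC[C@@H]3C=C[C@H](n4cc(C)c(=O)[nH]c4=O)O3)c2)c1` and compound 2 `COc1ccc(C(=O)c2ccccc2Cl)cc1OCC(=O)OC[C@@H]1C=C[C@H](n2cc(C)c(=O)[nH]c2=O)O1` have both been tested in a functional assay on HeLa cells (Homo sapiens) for antiproliferative activity, read by MTT assay, with a stated time of 48 h; on this read-out lower numbers stand for stronger inhibition and higher numbers for weaker inhibition. In this assay compound 1 gives 1580 nM, the lower of the two numbers, and compound 2 gives 45800 nM, a gap beyond the usual scatter. Compound 3 `COc1cc(OC)c(C(=O)c2ccc(OC)c(OC(=O)CCC(=O)OC[C@@H]3C=C[C@H](n4cc(C)c(=O)[nH]c4=O)O3)c2)cc1OC` differs from compound 1 in a single place: 2,4,5-trimethoxyphenyl in place of 3-methoxyphenyl on a carbonyl carbon. Among the compounds with values here, no measured pair shows what this change does, so the expectation rests on compound 1 alone. The step of a 2.0-fold lower number from compound 1 to compound 3 (0.30 log units; within the scatter) is expected to be modest and toward stronger inhibition. Compound 3 is accordingly estimated at 800 nM, within a range of 200 nM to 3200 nM.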

Compound 3, half-maximal inhibitory concentration: 2650 nM
For compound 3 the middle estimate is 3.3-fold (0.52 log units) below the measured one, within the range that was stated.
By their numbers in this assay, from the lowest: compounds 1 and 3 (each within the scatter of the next); then compound 2.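

In this assay, putting 2,4,5-trimethoxyphenyl in place of 3-methoxyphenyl on a carbonyl carbon gives a 1.7-fold higher number from compound 1 to compound 3 (0.22 log units; within the scatter) and so makes no clear difference. Within the data shown here, this is the first direct look at this position: it can carry the larger group, with its added methoxy groups, without a change beyond the scatter. No supporting measurement bears on this result. Still open, as far as these compounds go, is whether an amine or a carboxylic acid on this ring would shift the number, and what each methoxy group contributes alone.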